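Thiosemicarbazone series: pyrrole to thiophene at the imine carbon

The source may report more compounds than this note shows. Statements on the series, on what has been measured and on what is new or still open speak of the compounds shown alone.

Measured so far in a functional assay on MCF7 cells (Homo sapiens) for inhibition, read by sulforhodamine B assay, with a stated time of 48 h; a lower number here means a stronger inhibitor of growth, a higher number a weaker inhibitor of growth:
- compound 1, `CC1=CC[C@H](C(C)(C)NC(=S)N/N=C/c2ccc(F)cc2)CC1`: > 100000 nM (a limit of the assay, not a number)
- compound 2, `CC1=CC[C@H](C(C)(C)NC(=S)N/N=C/c2ccc[nH]2)CC1`: 11500 nM

Among the compounds with values here, compound 2 is the only member of the pair with a numerical value; it carries 1H-pyrrol-2-yl on the carbon with a double bond to nitrogen, and in this assay compound 2 gives 11500 nM. Compound 1 is recorded only as the limit of > 100000 nM in this assay, at which 1 of the 2 values shown sits. Within the data shown here, the one measured step at this position, an at least 8.6-fold lower number from compound 1 to compound 2 (0.93 log units; beyond the scatter), shows that the aromatic group on the imine carbon moves the number beyond the scatter.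

Compound 3, `CC1=CC[C@H](C(C)(C)NC(=S)N/N=C/c2cccs2)CC1`, differs from compound 2 by thiophen-2-yl in place of 1H-pyrrol-2-yl on a carbon with a double bond to nitrogen. Among the measured compounds shown here, no measured step covers this exact exchange; it is bracketed only by the step from the fluorophenyl to the pyrrole. The thiophene, a five-membered ring without the pyrrole's hydrogen-bond donor, is expected to place compound 3 between the two measured points, nearer compound 2. For compound 3 the estimate in this assay is 30000 nM, within 8000 nM to 100000 nM. The expected step is a 2.6-fold higher number from compound 2 to compound 3 (0.42 log units; beyond the scatter), a modest rise in the number, with a real chance that only a limit is returned.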

Compound 3, concentration for total growth inhibition: 11500 nM
For compound 3 the middle estimate is 2.6-fold (0.42 log units) above the measured one, and the stated range covers the measured number.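

In this assay, the exchange of 1H-pyrrol-2-yl for thiophen-2-yl on the carbon with a double bond to nitrogen shows no change at the digits printed from compound 2 to compound 3 (within the scatter), so the hydrogen-bond donor counted on the pyrrole leaves no readable mark on the number at this position. The thiophene compound also shows an at least 8.6-fold lower number from compound 1 to compound 3 (0.93 log units; beyond the scatter), which puts both five-membered aromatic rings apart from 4-fluorophenyl, not only the pyrrole. Compound 1 is recorded as a limit of the assay and not as a number, so the full size of this step stays unknown: the limit of > 100000 nM in this assay, at which 1 of the 3 values shown sits.

Open, on these data alone, is whether the five-membered ring itself matters or only the absence of 4-fluorophenyl, a question that plain phenyl, furan-2-yl or pyridin-2-yl on the same carbon would help to settle. Also open is how far this position tolerates other kinds of group, such as an amine or a carboxylic acid on the aromatic ring, since the compounds shown vary only the aromatic ring and leave the shared core unchanged.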